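The source may report more compounds than this note shows. Statements on the series, on what has been measured and on what is new or still open speak of the compounds shown alone.

Three compounds share one core and differ only in the group on one aromatic carbon, and all three were tested in a functional assay on HCT-116 cells (Homo sapiens) for antiproliferative activity, read by MTT assay, with a stated time of 24 h; on this read-out lower numbers stand for stronger inhibition and higher numbers for weaker inhibition. Compound 1 `COc1ccc(-c2noc(-c3ccccc3)n2)cc1OC1CCCC1`, which carries phenyl, gives > 1000000 nM. That value is a limit of the assay and not a number. Compound 2 `COc1ccc(-c2noc(C3CCCN3)n2)cc1OC1CCCC1`, which carries pyrrolidin-2-yl, gives 185000 nM. Compound 3 `COc1ccc(-c2noc(C3CCNCC3)n2)cc1OC1CCCC1`, which carries piperidin-4-yl, gives 1540 nM, the lowest number of the three and so the strongest inhibition here.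

Compound 4 `COc1ccc(-c2noc(-c3ccc(O)cc3)n2)cc1OC1CCCC1` has not yet been measured. It has 4-hydroxyphenyl in place of piperidin-4-yl on an aromatic carbon of the five-membered aromatic ring: 4-hydroxyphenyl in place of piperidin-4-yl on an aromatic carbon.

Two large steps show how much this group matters: an at least 640-fold lower number from compound 1 to compound 3 (2.81 log units; beyond the scatter) and a 120-fold lower number from compound 2 to compound 3 (2.08 log units; beyond the scatter). A smaller one, an at least 5.4-fold lower number from compound 1 to compound 2 (0.73 log units; beyond the scatter), points the same way. The first of these bears most directly, since phenyl, like 4-hydroxyphenyl, is a six-membered aromatic ring of carbon only. Among the compounds with values here, no measured compound shows what the added hydroxy group does, so a return all the way to the level of compound 1 is not assumed. A large move to a higher number in this assay is expected, estimated as a 97-fold higher number from compound 3 to compound 4 (1.99 log units; beyond the scatter). For compound 4 the expected value is 150000 nM, with an estimated range from 15000 nM to 1000000 nM.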

Compound 4, half-maximal inhibitory concentration: 270 nM
Beside the measured number, compound 4's estimate is 560-fold (2.74 log units) above it, outside the stated range (below it).
By their numbers in this assay, from the lowest: compound 4; then compound 3; then compound 2. At a limit, above all of these: compound 1.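

Replacing piperidin-4-yl with 4-hydroxyphenyl gives a 5.7-fold lower number from compound 3 to compound 4 (0.76 log units; beyond the scatter), so in this assay a six-membered aromatic ring of carbon only can give the lowest number in this set, and a non-aromatic ring with nitrogen is not needed at this position. The same group also compares well with the smaller nitrogen ring, with a 690-fold lower number from compound 2 to compound 4 (2.84 log units; beyond the scatter). Most striking is the single hydroxy group on the phenyl ring, which gives an at least 3700-fold lower number from compound 1 to compound 4 (3.56 log units; beyond the scatter), a step whose true size cannot be fixed because compound 1 stands at a limit and not at a number: the limit of > 1000000 nM in this assay, at which 1 of the 4 values shown sits.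

As far as these compounds go, what the hydroxy group contributes remains open, since a methoxy group, an amino group or a fluorine in its place would show whether another group on the phenyl ring can do the same. From the compounds shown here alone, it is also open whether a longer chain between the core and the 4-hydroxyphenyl group, or a carboxylic acid on the phenyl ring in place of the hydroxy group, would keep a number this low.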